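Drawing one ring stereocentre R instead of S

The source may report more compounds than this note shows. Statements on the series, on what has been measured and on what is new or still open speak of the compounds shown alone.

Compound 2 `CCO/C(O)=C1\C(COCCn2c(C)nc(C)c2C)=NC(C)=C(C(=O)OC)[C@H]1c1ccccc1Cl` stands at > 1000 nM in a functional assay (aorta) with Rattus norvegicus as the target (a higher number here means a weaker inhibitor, a lower number a stronger inhibitor), and this value is a limit of the assay, not a number. Compound 1 `CCO/C(O)=C1\C(COCCn2c(C)nc(C)c2C)=NC(C)=C(C(=O)OC)C1c1ccccc1Cl` gives 14 nM in this assay. The only difference between these two is the fact that one of compounds 1 and 2 is drawn with a defined configuration and the other without, at the place where they differ, and the measured result is an at least 71-fold higher number from compound 1 to compound 2 (1.85 log units; beyond the scatter). Compound 3 `CCO/C(O)=C1\C(COCCn2c(C)nc(C)c2C)=NC(C)=C(C(=O)OC)[C@@H]1c1ccccc1Cl` is the unmeasured counterpart of compound 2: the two compounds have the same atoms and bonds and differ only in configuration as drawn: 1 of 2 stereo elements differ; a stereocentre at a saturated ring carbon is drawn S in compound 2 and R in compound 3. Among the compounds with values here, only that one large measured step bears on this change. If compound 1, with no configuration drawn at that carbon, is a mixture of both forms, its 14 nM would have to come mainly from the form drawn R. A large step toward a lower number is therefore expected in this assay, estimated as an at least 140-fold lower number from compound 2 to compound 3 (2.15 log units; beyond the scatter). If the mixture reading holds, the number should also sit somewhat lower than the one for the mixture, though this rests on a single comparison. Compound 3 is expected at 7 nM, with an estimated range from 2.5 nM to 20 nM.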

Compound 3, half-maximal inhibitory concentration: 12 nM
Estimate against measurement, compound 3: 1.7-fold (0.23 log units) below; measured number inside the range.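

In this assay, redrawing the saturated ring carbon from S to R gives an at least 83-fold lower number from compound 2 to compound 3 (1.92 log units; beyond the scatter), so the configuration at this single carbon accounts for a large measured step between two fully drawn forms: the fact that compounds 2 and 3 differ only in the configuration as drawn. Compound 2 stands at > 1000 nM, and this value is a limit of the assay, not a number, so the step carries the same limit. The R form also gives a 1.2-fold lower number from compound 1 to compound 3 (0.07 log units; within the scatter), which places the compound drawn without a configuration and the one drawn R within the scatter of each other, so at this position the R form alone reaches what was seen for compound 1: the fact that one of compounds 1 and 3 is drawn with a defined configuration and the other without, at the place where they differ.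

On these data alone, how far compound 2 actually lies beyond its limit stays open, as does the composition of compound 1, and with them the true size of the gap between the two forms. As far as these compounds go, it is also open whether the same dependence on configuration would hold in this assay for a compound carrying an amine or a carboxylic acid on the shared core, since all three compounds here share the same atoms and bonds.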